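Second chloro on the shared core: two compound pairs

The source may report more compounds than this note shows. Statements on the series, on what has been measured and on what is new or still open speak of the compounds shown alone.

Compound 1 `ClCc1ccccc1Cn1cnc2c(Cl)nc(Cl)nc21` and compound 2 `ClCc1ccccc1Cn1cnc2c(Cl)ncnc21` share one core and differ at a single aromatic carbon. In a functional assay on HCT-116 cells (Homo sapiens) for cytotoxicity, read by sulforhodamine B assay, with a stated time of 48 h (a higher number here means a weaker inhibitor of growth, a lower number a stronger inhibitor of growth), compound 1 gives 190 nM, while compound 2 gives 1900 nM. The change from compound 2 to compound 1 is chloro in place of hydrogen on an aromatic carbon, and it produced a 10-fold lower number from compound 2 to compound 1 (1.00 log units; beyond the scatter). Compound 3 `ClCc1cccc(Cn2cnc3c(Cl)ncnc32)c1` has the same atoms as compound 2 joined differently; the difference between the two cores is not broken down here. In this assay compound 3 gives 1470 nM, which sits within the scatter of compound 2, whereas compound 1 gives a clearly lower number than compound 3. Compound 4 `ClCc1cccc(Cn2cnc3c(Cl)nc(Cl)nc32)c1` has not been measured and adds to compound 3 the change (chloro in place of hydrogen on an aromatic carbon). The surroundings of the entering chloro read the same for both pairs, so this is the same change made on a second core. Going by the values given here, the only measured instance of it is the pair of compound 2 and compound 1, so any expectation rests on one step alone, and the width of the range stays broad for that reason. Compound 4 is expected to give 160 nM in this assay, within a range from 60 nM to 450 nM. For compound 4 the expected step is a 9.2-fold lower number from compound 3 to compound 4 (0.96 log units; beyond the scatter) because a 10-fold lower number from compound 2 to compound 1 (1.00 log units; beyond the scatter) was the result of the same change on the core of compound 2.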

Compound 4, concentration for 50% growth inhibition: 1620 nM
Compound 4: middle estimate off by 10-fold (1.01 log units), on the low side, and the stated range ends below it.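

In this assay the step on the core of compound 3 is a 1.1-fold higher number from compound 3 to compound 4 (0.04 log units; within the scatter), so chloro in place of hydrogen on an aromatic carbon leaves this pair within the scatter. Set beside the earlier pair, the step does not carry from one core to the other, and a gain seen on one core cannot be assumed on the second: the same change on two cores in this assay, a 10-fold lower number (1.00 log units; beyond the scatter) from compound 2 to compound 1 and a 1.1-fold higher number (0.04 log units; within the scatter) from compound 3 to compound 4, 11-fold (1.04 log units) apart, beyond the scatter of two such steps
This rests on two pairs in one cell assay and does not show which difference between the two cores separates the outcomes, nor does it give a rule for any further core in the series.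

As far as these compounds go, whether an amine or a methoxy group on the same aromatic carbon, between two ring nitrogen atoms, would also respond differently on the two cores remains open. Also open is how far the split between the cores depends on the chloromethyl group carried by all the compounds shown, which a hydroxymethyl group in its place on both cores would begin to test.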